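The compounds below may be only part of what the source reports. "The series", "measured", "known", "first", "only" and "open" are said of these compounds alone.

Series notes. In an assay for inhibition of Nicotinamide phosphoribosyltransferase (Homo sapiens), read by mass spectrometry, with stated times of 15 min and 30 min (a higher number here means a weaker inhibitor, a lower number a stronger inhibitor), compound 1 `O=C(NCc1ccc(S(=O)(=O)c2ccccc2)cc1)c1ccc2ncncc2c1` gives 1900 nM, while compound 2 `O=C(NCc1ccc(S(=O)(=O)c2ccccc2C(F)(F)F)cc1)c1cc2cnccc2[nH]1` gives 24 nM; compound 2 therefore holds the lowest number of the two measured, and the gap to compound 1 lies beyond the scatter. Compound 3 `O=C(NCc1ccc(S(=O)(=O)c2ccc(F)c(F)c2)cc1)c1cc2cnccc2[nH]1` is not yet measured in this assay. Compared with compound 2 it carries 3,4-difluorophenyl in place of 2-(trifluoromethyl)phenyl on a sulfonyl sulfur. Within the data shown here, no measured pair shows such a change, so its size is unknown. The expected step is a 2.5-fold higher number from compound 2 to compound 3 (0.40 log units; beyond the scatter) toward a higher number. For compound 3 the estimate in this assay is 60 nM, with a range from 15 nM to 250 nM.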

Compound 3, half-maximal inhibitory concentration: 10 nM
Beside the measured number, compound 3's estimate is 6.0-fold (0.78 log units) above it; the measured number lies below the stated range.
By their numbers in this assay, from the lowest: compound 3; then compound 2; then compound 1.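

In this assay the group on a sulfonyl sulfur can change with the number staying low: 3,4-difluorophenyl in place of 2-(trifluoromethyl)phenyl gives a 2.4-fold lower number from compound 2 to compound 3 (0.38 log units; beyond the scatter) and so shows that trifluoromethyl is not required for a low number in this pair. Among these compounds, this is the first comparison that differs in one place only. No available data account for the step. As far as these compounds go, it remains open how a phenyl group carrying an amine or a carboxylic acid would read on a sulfonyl sulfur. From the compounds shown here alone, a cyclohexyl group there is equally open.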